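Changing the aryl group on the carbonyl: compound 4

The source may hold more compounds than are shown below. What is called first, only, known or untested is meant among the compounds shown, and "the series" means these compounds.

In a functional assay (aorta) with Rattus norvegicus as the target (a higher number here means a more potent compound, by a factor of ten per unit of this negative logarithm, a lower number a less potent compound), compound 1 `CC1(C)C=C(n2ccccc2=O)c2ccccc2O1` gives 5.43. Compound 2 `CC1(C)C=C(n2ccccc2=O)c2cc(C(=O)c3cccs3)ccc2O1` gives 6.4, and compound 3 `CC1(C)C=C(n2ccccc2=O)c2cc(C(=O)c3ccc([N+](=O)[O-])cc3)ccc2O1` gives 6.2. Among these three numbers compound 3 stands second highest: its nearest neighbour is compound 2, whose value lies within the scatter of that of compound 3, while its furthest is compound 1, whose value lies beyond the scatter. The two measured steps are a number 0.97 log units higher from compound 1 to compound 2 (beyond the scatter) and a number 0.20 log units lower from compound 2 to compound 3 (within the scatter), the first being the only one beyond the scatter.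

Compound 4 `CC1(C)C=C(n2ccccc2=O)c2cc(C(=O)c3ccccc3F)ccc2O1` differs from compound 3 in one place: 2-fluorophenyl in place of 4-nitrophenyl on a carbonyl carbon. The step bearing on this change is a number 0.20 log units lower from compound 2 to compound 3 (within the scatter), which likewise exchanged one aryl group for another on the same carbonyl carbon and stayed within the scatter. For compound 4 in this assay a step of a number 0.10 log units higher from compound 3 to compound 4 (within the scatter) is therefore expected, that is, nothing beyond the scatter in either direction. The estimate for compound 4 is 6.3, with an expected range from 5.8 to 6.8.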

Compound 4, logarithm of the reciprocal of the active concentration, log(1/C): 7.08
Compound 4: the middle estimate sits 0.78 log units below what was measured; measured number outside the range, above it.
By their numbers in this assay, from the lowest: compound 1; then compounds 3 and 2 (each within the scatter of the next); then compound 4.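

In this assay, the aryl group on the carbonyl carbon turns out to matter beyond the scatter: 2-fluorophenyl gives a number 0.88 log units higher from compound 3 to compound 4 (beyond the scatter) when it replaces 4-nitrophenyl and a number 0.68 log units higher from compound 2 to compound 4 (beyond the scatter) when it replaces thiophen-2-yl, whereas the earlier exchange of aryl groups at this place stayed within the scatter. Against the unsubstituted compound, (2-fluorophenyl)carbonyl in place of hydrogen on an aromatic carbon gives a number 1.65 log units higher from compound 1 to compound 4 (beyond the scatter), so this position can carry much more than the first acyl groups suggested. Nothing available explains why this aryl group stands apart.

The compounds shown do not separate the fluorine from the phenyl ring carrying it, and a plain phenyl, 4-fluorophenyl or 2-chlorophenyl would bear on that. They also leave open whether the carbonyl itself is needed, which a methylene in its place would test.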